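Replacing a Methoxy Group with a Methoxypyridinyl Ring

A few compounds are considered here, and "the series" means these few. Any claim that something is new, unique, unknown or untested is made for them only; others in the source may bear on it.

Compound 1 has the structure `COc1cc(C(O)(C(F)(F)F)C(F)(F)F)cnc1N1CCN(S(=O)(=O)c2ccc(N)nc2)CC1`. In an ADME assay (liver) for metabolic stability, with Liver microsome (Homo sapiens) as the target, using microsomes and NADPH, with a stated time of 30 min, tested at 1 uM (a lower number here means slower removal, a higher number faster removal of the compound), compound 1 gives < 14 mL.min-1.g-1, which is a limit of the measurement rather than a number, so where compound 1 stands is known only as that limit. Compound 2, `Nc1ccc(S(=O)(=O)N2CCN(c3ncc(C(O)(C(F)(F)F)C(F)(F)F)cc3-c3ccccc3O)CC2)cn1`, gives 22 mL.min-1.g-1 in this assay. The step between them, an at least 1.5-fold higher number from compound 1 to compound 2 (0.19 log units; that floor lies within the scatter), rests on (the limit of < 14 mL.min-1.g-1 in this assay, at which 1 of the 2 values shown sits), so its true size is uncertain.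

Compound 3, `COc1ccc(-c2cc(C(O)(C(F)(F)F)C(F)(F)F)cnc2N2CCN(S(=O)(=O)c3ccc(N)nc3)CC2)cn1`, is not yet measured. It differs from compound 1 by 6-methoxypyridin-3-yl in place of methoxy on an aromatic carbon. The step from compound 1 to compound 2 also swaps the methoxy for an aromatic ring at this same position, and it bears most directly on the change here. On that basis compound 3 is expected to show a step of an at least 1.4-fold higher number from compound 1 to compound 3 (0.15 log units; that floor lies within the scatter), a modest rise that may still fall within the scatter. The estimate for compound 3 is 20 mL.min-1.g-1, within a range from 8 mL.min-1.g-1 to 45 mL.min-1.g-1.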

Compound 3, intrinsic clearance in microsomes: 25 mL.min-1.g-1
Compound 3: middle estimate off by 1.3-fold (0.10 log units), on the low side; low and high end bracket the measured number.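

With a second aromatic ring at this position, 6-methoxypyridin-3-yl, the change away from the methoxy group in this assay gives an at least 1.7-fold higher number from compound 1 to compound 3 (0.25 log units; that floor lies within the scatter). The two rings read alike, with a 1.1-fold higher number from compound 2 to compound 3 (0.06 log units; within the scatter), so in this pair, swapping 2-hydroxyphenyl for 6-methoxypyridin-3-yl leaves no difference that can be told from the scatter. Compound 1 gives only a limit, so the true size of the step away from it remains uncertain: the limit of < 14 mL.min-1.g-1 in this assay, at which 1 of the 3 values shown sits.

The compounds shown leave open whether the similar readings of compound 2 and compound 3 extend to other aromatic rings, such as an unsubstituted phenyl ring. They also leave open how a non-aromatic group at this position, such as a small amine or a cyclopropyl ring, would compare.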